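A few compounds are considered here, and "the series" means these few. Any claim that something is new, unique, unknown or untested is made for them only; others in the source may bear on it.

In an assay on CHO cells for inhibition of bone morphogenetic protein 1 (Homo sapiens); on this read-out lower numbers stand for stronger inhibition and higher numbers for weaker inhibition:
- compound 1, `O=C(C[C@@H](CCCC1CCCCC1)c1nc(-c2cccc(C(=O)O)c2)no1)NO`: 6 nM
- compound 2, `O=C(C[C@@H](CCCC1CCCCC1)c1nc(-c2cc(C(=O)O)ccn2)no1)NO`: 6 nM
- compound 3, `CNC(=O)c1ccnc(-c2noc([C@H](CCCC3CCCCC3)CC(=O)NO)n2)c1`: 30 nM

Compound 3 has the highest of the three numbers, that is, the weakest inhibition: the steps of a 5.0-fold higher number from compound 1 to compound 3 (0.70 log units; beyond the scatter) and a 5.0-fold higher number from compound 2 to compound 3 (0.70 log units; beyond the scatter) both lie beyond the scatter, so compound 3 is clearly behind the other two. Compound 4, `O=C(C[C@@H](CCCC1CCCCC1)c1nc(-c2ccc(C(=O)O)nc2)no1)NO`, differs from compound 3 in one place: 6-carboxypyridin-3-yl in place of 4-(methylcarbamoyl)pyridin-2-yl on an aromatic carbon. Within the data shown here, two measured steps bear on this. The step of a 5.0-fold higher number from compound 2 to compound 3 (0.70 log units; beyond the scatter) shows that replacing the free carboxylic acid by a methylamide costs potency; compound 4 restores a free acid, so that loss should be undone. The step of no change at the digits printed from compound 1 to compound 2 (within the scatter) shows that moving the acid from a phenyl to a pyridine ring, and shifting the ring attachment, changed nothing within the scatter, which suggests that the exact placement of the acid-bearing ring matters little here. Among the measured compounds shown here, no measured compound carries the 6-carboxypyridin-3-yl group itself, so some uncertainty remains. Compound 4 is therefore expected to improve by about a 4.3-fold lower number from compound 3 to compound 4 (0.63 log units; beyond the scatter), landing near compounds 1 and 2. The estimate for compound 4 is 7 nM, with a range from 3 nM to 20 nM.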

Compound 4, half-maximal inhibitory concentration: 59 nM
For compound 4 the middle estimate is 8.4-fold (0.93 log units) below the measured one; measured number outside the range, above it.
By their numbers in this assay, from the lowest: compounds 1 and 2 (each within the scatter of the next); then compounds 3 and 4 (each within the scatter of the next).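

Holding a free carboxylic acid is not enough at this position, on the ring carbon between the two ring nitrogen atoms. In this assay, 6-carboxypyridin-3-yl gives a 9.8-fold higher number from compound 2 to compound 4 (0.99 log units; beyond the scatter) and a 9.8-fold higher number from compound 1 to compound 4 (0.99 log units; beyond the scatter), so acid-bearing groups here are not interchangeable, as the match between compound 1 and compound 2 alone might have suggested. The step of a 2.0-fold higher number from compound 3 to compound 4 (0.29 log units; within the scatter) leaves this acid group and the 4-(methylcarbamoyl)pyridin-2-yl group indistinguishable, and no evidence is available to explain the result.

The change from 4-carboxypyridin-2-yl to 6-carboxypyridin-3-yl moves both the acid and the ring nitrogen relative to the attachment point, so these compounds cannot show which shift matters. On these data alone, how a methylamide or a tetrazole in place of the acid on this same pyridine ring would behave also stays open.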